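The compounds below may be only part of what the source reports. "The series", "measured", "known", "first", "only" and "open" are said of these compounds alone.

Three compounds were measured in an assay on HepG2 cells for displacement of a labelled ligand from Alpha-2C adrenergic receptor (Homo sapiens), tested at 0.1 uM; a higher number here means more inhibition at the concentration tested (going by the name of the read-out), a lower number less inhibition. Compound 1 `COc1cc2c(cc1OC)CN(Cc1ccc(OC)c3oc(-c4cccnc4)cc13)CC2` gives 62%, compound 2 `COc1cc2c(cc1OC)CN(Cc1ccc(OC)c3oc(-c4cccc(C#N)c4)cc13)CC2` gives 42%, and compound 3 `COc1cc2c(cc1OC)CN(Cc1ccc(OC)c3oc(C(=O)NCCO)cc13)CC2` gives 6%. Compound 2 thus stands second highest of the three: the step that leads down to it is a number 20 percentage points lower from compound 1 to compound 2 (beyond the scatter), and the step that leads down from it is a number 36 percentage points lower from compound 2 to compound 3 (beyond the scatter). Compound 4 `COc1cc2c(cc1OC)CN(Cc1ccc(OC)c3oc(C(=O)NCCNC(C)=O)cc13)CC2` differs from compound 2 in one place: (2-acetamidoethyl)carbamoyl in place of 3-cyanophenyl on an aromatic carbon. Within the data shown here, the step that bears on this change is the one to compound 3, where a carbamoyl group also replaced the 3-cyanophenyl ring; it was a number 36 percentage points lower from compound 2 to compound 3 (beyond the scatter), with a number 56 percentage points lower from compound 1 to compound 3 (beyond the scatter) pointing the same way. A large downward step is therefore expected, a number 34 percentage points lower from compound 2 to compound 4 (beyond the scatter), and compound 4 is estimated at 8%, within a range from 0% to 25%.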

Compound 4, a percentage reported as inhibition, at one concentration (the size of the read-out at that concentration, not a potency): 9%
Compound 4: middle estimate off by 1 percentage points, on the low side, and the stated range covers the measured number.
By their numbers in this assay, from the lowest: compounds 3 and 4 (each within the scatter of the next); then compound 2; then compound 1.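

On the aromatic carbon next to the ring oxygen, (2-acetamidoethyl)carbamoyl in this assay stands far under both ring-bearing compounds, with a number 33 percentage points lower from compound 2 to compound 4 (beyond the scatter) and a number 53 percentage points lower from compound 1 to compound 4 (beyond the scatter), so the low reading of compound 3 is not tied to its hydroxy end. Acetamido in place of hydroxy gives a number 3 percentage points higher from compound 3 to compound 4 (within the scatter), so these two chain ends cannot be told apart here. Nothing available explains these readings. From the compounds shown here alone, whether an amine or a carboxylic acid at the chain end, or a longer chain, would restore the reading remains open.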